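Extending the oxanyl substituent on the pyridinone nitrogen

The compounds below may be only part of what the source reports. "The series", "measured", "known", "first", "only" and "open" are said of these compounds alone.

Measured compounds:
compound 1, `CN(C)C(=O)CN1CCC(c2cc3c(-c4ccc(=O)n(C)c4)ccnc3[nH]2)CC1`, 1.1
compound 2, `CC(C)n1cc(-c2ccnc3[nH]c(C4CCNCC4)cc23)ccc1=O`, -0.2
compound 3, `CN(C)C(=O)CN1CCC(c2cc3c(-c4ccc(=O)n(C5CCOCC5)c4)ccnc3[nH]2)CC1`, 1.1

In a physicochemical assay for lipophilicity, using the shake flask method, measured as octanol-water partition, at pH 7.4 (a higher number here means a more lipophilic compound, a lower number a more polar compound), compound 3 stands level with compound 1 at the digits shown, the two together giving the highest numbers of the three. For the measured compounds named here, compound 2 sits well below compound 3, with a gap beyond the scatter, but no single-point step links them. Going by the values given here, the one step that does bear on the present question is no change at the digits printed from compound 1 to compound 3 (within the scatter), which replaced a methyl on the same aromatic nitrogen with the oxan-4-yl group.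

Compound 4, `CN(C)C(=O)CN1CCC(c2cc3c(-c4ccc(=O)n(CCC5CCOCC5)c4)ccnc3[nH]2)CC1`, follows compound 3 by one change: 2-(oxan-4-yl)ethyl in place of oxan-4-yl on an aromatic nitrogen. Among the compounds with values here, the only comparable step, from methyl to oxan-4-yl, moved nothing beyond the scatter, so the data give no firm direction. The entering group carries more heavy atoms than the leaving one, and compound 4 is expected to come out slightly higher, by a number 0.30 log units higher from compound 3 to compound 4 (within the scatter), a step that may still fall within the scatter. Compound 4 is therefore estimated at 1.4, with a range from 1 to 1.9.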

Compound 4, distribution coefficient: 1.5
For compound 4 the middle estimate is 0.10 log units below the measured one; low and high end bracket the measured number.
By their numbers in this assay, from the lowest: compound 2; then compounds 1 and 3 (each within the scatter of the next); then compound 4.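

In this assay the 2-(oxan-4-yl)ethyl group gives the first step on this aromatic nitrogen that clears the scatter, with a number 0.40 log units higher from compound 3 to compound 4 (beyond the scatter) in the shared series, whereas the earlier change had shown no change at the digits printed from compound 1 to compound 3 (within the scatter) and no more. Set against methyl directly, the same group gives a number 0.40 log units higher from compound 1 to compound 4 (beyond the scatter) on the same core, so oxan-4-yl did not separate from methyl at this position while 2-(oxan-4-yl)ethyl did. Nothing given here accounts for this difference.

The compounds shown leave open whether the rise follows the added chain or the ring, a question that a 2-cyclohexylethyl group on the same nitrogen would address. Going by these compounds, how a longer chain, or an amine in place of the oxan-4-yl ring, would read in this assay also remains open.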